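Moving the halogen on the hydroxyphenyl ring

A few compounds are considered here, and "the series" means these few. Any claim that something is new, unique, unknown or untested is made for them only; others in the source may bear on it.

Of the compounds shown here, three built on one shared core have been measured in a functional assay on PC-3 cells (Homo sapiens) for inhibition; on this read-out lower numbers stand for stronger inhibition and higher numbers for weaker inhibition. Compound 3 `Cc1c(C(=O)N/N=C\c2cc(F)ccc2O)oc2cccc(O)c12` gives 3170 nM and stands lowest of the two numbers available. Compound 1 `Cc1c(C(=O)N/N=C\c2cccc(F)c2O)oc2cccc(O)c12` gives 12700 nM; the change between them is a 4.0-fold lower number from compound 1 to compound 3 (0.60 log units; beyond the scatter). Compound 2 `Cc1c(C(=O)N/N=C\c2ccccn2)oc2cccc(O)c12` reaches only a limit of the assay, >= 40000 nM, and so supplies no number. The two remaining steps are an at least 3.1-fold higher number from compound 1 to compound 2 (0.49 log units; beyond the scatter) and an at least 12-fold lower number from compound 2 to compound 3 (1.10 log units; beyond the scatter), both of which swap the whole hydroxyphenyl ring for pyridin-2-yl.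

Compound 4 `Cc1c(C(=O)N/N=C\c2ccc(Br)cc2O)oc2cccc(O)c12` differs from compound 3 in a single place: 4-bromo-2-hydroxyphenyl in place of 5-fluoro-2-hydroxyphenyl on a carbon with a double bond to nitrogen. Among the measured compounds shown here, no measured step exchanges one halogen for another or places a substituent at the 4-position of the hydroxyphenyl ring. The closest comparison is the shift of fluorine within that ring, a 4.0-fold lower number from compound 1 to compound 3 (0.60 log units; beyond the scatter), a modest step, whereas the large steps arose only when the ring itself was replaced. Since the hydroxyphenyl ring is kept here and only the halogen and its position change, a step no larger than modest, of uncertain direction, is expected in this assay: a 1.6-fold higher number from compound 3 to compound 4 (0.20 log units; within the scatter). Compound 4 is estimated at 5000 nM, with a range from 1500 nM to 16000 nM.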

Compound 4, half-maximal inhibitory concentration: 2050 nM
The estimate for compound 4 lay 2.4-fold (0.39 log units) above the measured number, and the stated range covers the measured number.
By their numbers in this assay, from the lowest: compounds 4 and 3 (each within the scatter of the next); then compound 1. At a limit, above all of these: compound 2.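

In this assay, the step of a 1.5-fold lower number from compound 3 to compound 4 (0.19 log units; within the scatter) shows that changing the halogen and its position together leaves the two compounds indistinguishable, so a bromine on this ring is tolerated as well as the fluorine of 5-fluoro-2-hydroxyphenyl. Among the compounds shown here, the step of a 6.2-fold lower number from compound 1 to compound 4 (0.79 log units; beyond the scatter) now gives a second comparison beyond the scatter for the 3-fluoro-2-hydroxyphenyl group of compound 1, which until now had only one measured hydroxyphenyl neighbour for comparison. The step of an at least 19-fold lower number from compound 2 to compound 4 (1.29 log units; beyond the scatter) is large, yet its starting point is a limit and not a number: the limit of >= 40000 nM in this assay, at which 1 of the 4 values shown sits.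

Since the halogen and its position change in one step, the compounds shown cannot separate the contribution of either one. Going by these compounds, it also remains open whether a group of another kind, such as an amine or a methoxy group in place of the bromine of 4-bromo-2-hydroxyphenyl, would keep the number in this range.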